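A few compounds are considered here, and "the series" means these few. Any claim that something is new, unique, unknown or untested is made for them only; others in the source may bear on it.

Measured compounds:
- compound 1 `O=C1C=C(c2ccc(O)cc2O[C@@H]2O[C@H](CO)[C@@H](O)[C@H](O)[C@H]2O)C(Cc2ccc(O)cc2)O1`: 39.8 ug/mL
- compound 2 `COc1ccc(C2=CC(=O)OC2Cc2ccc(O)cc2)c(O[C@@H]2O[C@H](CO)[C@@H](O)[C@H](O)[C@H]2O)c1`: 46.9 ug/mL

In a physicochemical assay, with a stated time of 20 min (a lower number here means a stronger inhibitor, a higher number a weaker inhibitor), compound 1 gives 39.8 ug/mL, and compound 2 gives 46.9 ug/mL. Compound 1 has the lower of the two numbers, but the step of a 1.2-fold higher number from compound 1 to compound 2 (0.07 log units; within the scatter) is within the scatter, so the two compounds cannot be told apart on this evidence. Compound 3 `O=C1C=C(c2ccc(O)cc2O)C(Cc2ccc(O)cc2)O1` differs from compound 1 at one place: hydrogen in place of 3,4,5-trihydroxy-6-(hydroxymethyl)oxan-2-yl on an oxygen on an aromatic ring. Among the compounds with values here, the only measured step, a 1.2-fold higher number from compound 1 to compound 2 (0.07 log units; within the scatter), concerns a methyl in place of hydrogen on an oxygen on an aromatic ring, a different kind of change from the loss of the sugar unit, and it stayed within the scatter. Within the data shown here, no measured step therefore bears directly on this change, and the expectation rests on little. Compound 3 is estimated at 28 ug/mL, with a range from 10 ug/mL to 80 ug/mL. For compound 3 the expected step from compound 1 is a 1.4-fold lower number from compound 1 to compound 3 (0.15 log units; within the scatter), a change that may well fall within the scatter.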

Compound 3, half-maximal inhibitory concentration: 38.5 ug/mL
Compound 3: the middle estimate sits 1.4-fold (0.14 log units) below what was measured; low and high end bracket the measured number.
By their numbers in this assay, from the lowest: compounds 3, 1 and 2 (each within the scatter of the next).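

Taking the entire 3,4,5-trihydroxy-6-(hydroxymethyl)oxan-2-yl group off the oxygen on the aromatic ring and leaving hydrogen there gives a 1.0-fold lower number from compound 1 to compound 3 (0.01 log units; within the scatter) in this assay. The earlier pair involved only a methyl in place of hydrogen, whereas this step shows that compound 1 and compound 3 cannot be told apart in this assay even though a group of 11 heavy atoms, with 5 defined stereocentres, is absent from compound 3. No measurement is available that would explain this result.

From the compounds shown here alone, whether a carboxymethyl group or an aminoethyl chain on this oxygen would give a number distinct from that of compound 3 remains open. Going by these compounds, it is also open whether a methyl on the other oxygen, as in compound 2, would stay within the scatter without the sugar unit.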